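This account rests on a few compounds, and the source may have more. Where it says the series, first, only, none or still open, it means among the compounds named here.

Two analogues on the shared core have been measured. Compound 1 `NCCCCCCOc1ccc2c(=O)c(-c3ccc(O)cc3)coc2c1` gives 100 nM in an assay (Cricetulus griseus) for inhibition of aldehyde dehydrogenase, mitochondrial (Homo sapiens); a lower number here means a stronger inhibitor, a higher number a weaker inhibitor; compound 2 `CCOC(=O)COc1ccc2c(=O)c(-c3ccc(O)cc3)coc2c1` gives 130 nM in this assay. On these two numbers compound 2 sits at the upper end, but the gap to compound 1, a 1.3-fold higher number from compound 1 to compound 2 (0.11 log units; within the scatter), means the two compounds cannot be told apart. Compound 3 `CCCCC(Oc1ccc2c(=O)c(-c3ccc(O)cc3)coc2c1)C(=O)OCC` awaits measurement; it differs from compound 2 in butyl in place of hydrogen on a saturated chain carbon bound to a carbonyl carbon and an oxygen on an aromatic ring. Among the measured compounds shown here, the single measured step, a 1.3-fold higher number from compound 1 to compound 2 (0.11 log units; within the scatter), alters a different part of the molecule and leaves that chain carbon untouched, so no measured pair speaks to substitution there. Without a guiding step, a shift beyond the scatter is not expected in either direction, and compound 3 is estimated at 130 nM, with a range of 45 nM to 400 nM. The expected step from compound 2 is therefore no change at the digits printed from compound 2 to compound 3 (within the scatter).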

Compound 3, half-maximal inhibitory concentration: 4500 nM
Beside the measured number, compound 3's estimate is 35-fold (1.54 log units) below it; the measured number lies above the stated range.
By their numbers in this assay, from the lowest: compounds 1 and 2 (each within the scatter of the next); then compound 3.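

The saturated chain carbon bound to a carbonyl carbon and an oxygen on an aromatic ring is a place where the number in this assay responds strongly: butyl in place of hydrogen there gives a 35-fold higher number from compound 2 to compound 3 (1.54 log units; beyond the scatter), with the weaker compound carrying the added chain. Among the compounds shown here, the only earlier step, a 1.3-fold higher number from compound 1 to compound 2 (0.11 log units; within the scatter), showed no separation at all, so this is the first change to register beyond the scatter. Nothing at hand accounts for the size of this step.

Open, from the compounds shown here alone, is whether the step depends on chain length, which methyl or propyl in place of hydrogen on the same carbon would address. Also open, going by these compounds, is whether a carboxylic acid in place of the ethyl ester of compound 3 would keep the same high number.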